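Aryl Substituent Exchange on the Piperazine of Compound 1

This account rests on a few compounds, and the source may have more. Where it says the series, first, only, none or still open, it means among the compounds named here.

Measured so far:
compound 1 `COC(=O)C1=C(C)NC(=O)N(C(=O)NCCCN2CCN(c3ccccc3OC)CC2)C1c1ccc(F)c(F)c1` — 31 nM
compound 2 `COC(=O)C1=C(C)NC(=O)N(C(=O)NCCCN2CCN(c3cccc([N+](=O)[O-])c3)CC2)C1c1ccc(F)c(F)c1` — 340 nM

In an assay on liver for binding affinity to Alpha-1D adrenergic receptor (Homo sapiens), using microsomes (a higher number here means a weaker inhibitor, a lower number a stronger inhibitor), compound 1 gives 31 nM, the lowest of the two numbers measured. Going by the values given here, compound 2 gives 340 nM, and the step of an 11-fold higher number from compound 1 to compound 2 (1.04 log units; beyond the scatter) is the only measured step in the set.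

Compound 3 `COC(=O)C1=C(C)NC(=O)N(C(=O)NCCCN2CCN(c3ccccc3Cl)CC2)C1c1ccc(F)c(F)c1` differs from compound 1 by chloro in place of methoxy on an aromatic carbon. Among the compounds with values here, the one measured step swaps the whole aryl group for a differently substituted one, so it does not bear directly on a chloro-for-methoxy exchange at the same place; it shows only that the aryl substituent can move this assay by a large amount. Within the data shown here, with no step of the same kind measured, the expectation for compound 3 is a step within or close to the scatter, leaning toward a slightly higher number given that compound 1 is the lowest so far. Compound 3 is therefore expected to give 50 nM, with a range from 20 nM to 150 nM, which corresponds to an expected 1.6-fold higher number from compound 1 to compound 3 (0.21 log units; within the scatter).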

Compound 3, inhibition constant: 14 nM
Beside the measured number, compound 3's estimate is 3.6-fold (0.55 log units) above it; measured number outside the range, below it.
By their numbers in this assay, from the lowest: compound 3; then compound 1; then compound 2.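

In this assay, the methoxy on the aromatic carbon is not required for the low number of compound 1: chloro in its place gives a 2.2-fold lower number from compound 1 to compound 3 (0.35 log units; beyond the scatter), a modest step, and compound 3 is now the strongest of the set. The exchange of 3-nitrophenyl for 2-chlorophenyl gives a 24-fold lower number from compound 2 to compound 3 (1.39 log units; beyond the scatter), larger than the step from the 2-methoxyphenyl compound to the same 3-nitrophenyl compound, so the aryl group on the piperazine nitrogen spans a wide range in this assay. Nothing available here accounts for either step.

The 3-nitrophenyl and 2-chlorophenyl groups differ in both substituent and ring place, so the contribution of each stays unseparated; a 3-chlorophenyl or 2-nitrophenyl group would bear on this. From the compounds shown here alone, whether 2-fluorophenyl or 2-methylphenyl would follow 2-chlorophenyl also remains open.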